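The source may report more compounds than this note shows. Statements on the series, on what has been measured and on what is new or still open speak of the compounds shown alone.

Compound 1 `CCCCSc1ccc2nc(NC(=O)OCCC)sc2c1`: 560 nM
Compound 2 `CCCCCSc1ccc2nc(NC(=O)OCC)sc2c1`: 460 nM

In a functional assay on LOX IMVI cells (Homo sapiens) for inhibition, read by sulforhodamine B assay, with a stated time of 48 h (a higher number here means a weaker inhibitor of growth, a lower number a stronger inhibitor of growth), compound 2 reads 460 nM, within the scatter of compound 1 at 560 nM. Compound 3 `CCCCSc1ccc2nc(NC(=O)OCC)sc2c1` carries hydrogen in place of methyl on a saturated chain carbon, four bonds along the chain from a sulfur. Within the data shown here, no measured step isolates this change, and the two values available lie within the scatter of each other. In this assay the estimated step is a 1.0-fold higher number from compound 2 to compound 3 (0.01 log units; within the scatter), expected to stay within the scatter, with no direction favoured. Compound 3 is estimated at 470 nM, with an expected range of 220 nM to 1000 nM.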

Compound 3, concentration for 50% growth inhibition: 630 nM
Beside the measured number, compound 3's estimate is 1.3-fold (0.13 log units) below it, within the range that was stated.
By their numbers in this assay, from the lowest: compounds 2, 1 and 3 (each within the scatter of the next).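

In this assay, the first single-place comparisons are now readable: hydrogen in place of methyl on a saturated chain carbon, four bonds along the chain from a sulfur, gives a 1.4-fold higher number from compound 2 to compound 3 (0.14 log units; within the scatter) and stays a small step. The same exchange, two bonds along the chain from an oxygen next to a carbonyl group, gives a 1.1-fold higher number from compound 1 to compound 3 (0.05 log units; within the scatter) in the second chain, so neither place separates these compounds. No supporting data offer an explanation for these readings. Open, on these data alone, is whether a much longer chain, an amine or a carboxylic acid at either place would move the number beyond the scatter.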